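Chlorophenyl placement in a bis-piperazine propanamide series

The source may hold more compounds than are shown below. What is called first, only, known or untested is meant among the compounds shown, and "the series" means these compounds.

Compound 1 `O=C(CCN1CCN(c2cccc(Cl)c2)CC1)N1CCN(c2ccccc2)CC1` in an assay on cells for displacement of a labelled ligand from 5-hydroxytryptamine receptor 7 (Homo sapiens), read by scintillation counting, with a stated time of 30 min (a lower number here means a stronger inhibitor, a higher number a weaker inhibitor), gives 32.7 nM.
Compound 2 `O=C(CCN1CCN(c2ccc(Cl)cc2)CC1)N1CCN(c2ccccc2)CC1` gives 462 nM.
Compound 3 `O=C(CCN1CCN(c2cccc(Cl)c2)CC1)N1CCN(c2cccc(Cl)c2)CC1` gives 2760 nM.

Compound 3 stands at the highest number of the three, beyond the scatter from both others; against the shared parent the step is an 84-fold higher number from compound 1 to compound 3 (1.93 log units; beyond the scatter). Compound 4 `O=C(CCN1CCN(c2ccc(Cl)cc2)CC1)N1CCN(c2cccc(Cl)c2)CC1` differs from compound 3 by 4-chlorophenyl in place of 3-chlorophenyl on an amine nitrogen in a ring. Going by the values given here, one measured step bears directly on this change, the same swap at the same place: a 14-fold higher number from compound 1 to compound 2 (1.15 log units; beyond the scatter), a large move to a higher number. The step from compound 3 to compound 4 is therefore expected to be upward as well, estimated at a 5.4-fold higher number from compound 3 to compound 4 (0.74 log units; beyond the scatter), possibly somewhat smaller given the already high starting point. Compound 4 is expected at 15000 nM, with a range of 4000 nM to 60000 nM.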

Compound 4, inhibition constant: 2370 nM
For compound 4 the middle estimate is 6.3-fold (0.80 log units) above the measured one, and the stated range ends above it.
By their numbers in this assay, from the lowest: compound 1; then compound 2; then compounds 4 and 3 (each within the scatter of the next).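

The effect of 4-chlorophenyl in place of 3-chlorophenyl on this ring nitrogen depends on the core that carries it: the same change on two cores in this assay, a 14-fold higher number (1.15 log units; beyond the scatter) from compound 1 to compound 2 and a 1.2-fold lower number (0.07 log units; within the scatter) from compound 3 to compound 4, 16-fold (1.22 log units) apart, beyond the scatter of two such steps. On the chlorinated core the swap gives a 1.2-fold lower number from compound 3 to compound 4 (0.07 log units; within the scatter), so the two chlorine placements are not separated there. Chloro in place of hydrogen on an aromatic carbon still gives a 5.1-fold higher number from compound 2 to compound 4 (0.71 log units; beyond the scatter), and this step also differs with the core: the same change on two cores in this assay, an 84-fold higher number (1.93 log units; beyond the scatter) from compound 1 to compound 3 and a 5.1-fold higher number (0.71 log units; beyond the scatter) from compound 2 to compound 4, 16-fold (1.22 log units) apart, beyond the scatter of two such steps.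

Open, as far as these compounds go, is whether this dependence on the core holds with fluoro or methoxy in place of chloro, or with a longer chain in the linker.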